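Dropping the trifluoromethyl from the benzamide of compound 2

The source may hold more compounds than are shown below. What is called first, only, known or untested is meant among the compounds shown, and "the series" means these compounds.

Among the measured compounds shown here, compound 2 `COc1cc(-c2nn(-c3cccc(NC(=O)c4cccc(C(F)(F)F)c4)c3)cc2-c2ccncc2)ccc1Cl` gives 2290 nM in a functional assay on SK-OV-3 cells (Homo sapiens) for inhibition, read by sulforhodamine B assay, with a stated time of 48 h (on this read-out lower numbers stand for stronger inhibition of growth and higher numbers for weaker inhibition of growth), the highest of the three numbers measured so far. For the measured compounds named here, compound 1 `COc1cc(-c2nn(-c3cccc(NC(=O)Nc4cc(C(F)(F)F)cc(C(F)(F)F)c4)c3)cc2-c2ccncc2)ccc1Cl` gives 1090 nM and compound 3 `O=C(Nc1cccc(-n2cc(-c3ccncc3)c(-c3ccc(Cl)c(O)c3)n2)c1)Nc1cc(C(F)(F)F)cc(C(F)(F)F)c1` gives 1350 nM; the only single-point step measured, a 1.2-fold higher number from compound 1 to compound 3 (0.09 log units; within the scatter), concerns an oxygen substituent on the shared core and does not touch the benzamide. Compound 4 `COc1cc(-c2nn(-c3cccc(NC(=O)c4ccccc4)c3)cc2-c2ccncc2)ccc1Cl` differs from compound 2 by hydrogen in place of trifluoromethyl on an aromatic carbon. Going by the values given here, no measured step bears on removing this group, so the expectation rests on compound 2 alone and is loose. Compound 4 is expected to give about 3500 nM, between 1400 nM and 9000 nM, a step estimated at a 1.5-fold higher number from compound 2 to compound 4 (0.18 log units; within the scatter), with no change beyond the scatter the most likely outcome.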

Compound 4, concentration for 50% growth inhibition: 1070 nM
Beside the measured number, compound 4's estimate is 3.3-fold (0.51 log units) above it, and the stated range ends above it.
By their numbers in this assay, from the lowest: compounds 4, 1, 3 and 2 (each within the scatter of the next, the first and the last beyond it).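

In this assay, among the compounds shown here, the change from 3-(trifluoromethyl)phenyl to phenyl gives a 2.1-fold lower number from compound 2 to compound 4 (0.33 log units; beyond the scatter) and so provides the first measured step at this place, modest in size but beyond the scatter. Growth inhibition here does not depend on keeping the trifluoromethyl, since the plain benzoyl compound carries the lower number. (Nothing at hand explains this step)

As far as these compounds go, whether an amine or a carboxylic acid at this place would lower the number further stays open. So does whether removing trifluoromethyl from compound 1 would give a step of similar size.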